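Styryl in place of hydroxyphenyl on the shared core

The compounds below may be only part of what the source reports. "The series", "measured", "known", "first", "only" and "open" are said of these compounds alone.

Measured compounds:
- compound 1 `Cc1ccc(C2C(C#N)=C(N)N(c3ccc(S(N)(=O)=O)cc3)C3=C2CCCC3)cc1` — 80%
- compound 2 `N#CC1=C(N)N(c2ccc(S(N)(=O)=O)cc2)C2=C(CCCC2)C1c1ccc(O)cc1` — 60%

In a functional assay on Ehrlich cells (Mus musculus) for cytotoxicity, read by trypan blue exclusion, with a stated time of 2 h, tested at 50 ug/mL (a lower number here means a weaker effect, a higher number a stronger effect of the compound at the concentration tested), compound 1 gives 80%, and compound 2 gives 60%. Going by the values given here, compound 2 therefore stands lowest of the two numbers; the only step measured so far is a number 20 percentage points lower from compound 1 to compound 2 (beyond the scatter), a modest move beyond the scatter.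

Compound 3 `N#CC1=C(N)N(c2ccc(S(N)(=O)=O)cc2)C2=C(CCCC2)C1/C=C/c1ccccc1` has not yet been measured in this assay. Its difference from compound 2 is 2-phenylethenyl in place of 4-hydroxyphenyl on a saturated ring carbon. Among the compounds with values here, the one measured step concerns a hydroxy for a methyl on the aromatic ring that sits on this same ring carbon, so it bears on the change only loosely: compound 3 likewise loses the hydroxy, but the whole aryl group is exchanged for a 2-phenylethenyl group, for which there is no precedent in the pair.

Given that the removal of the hydroxy-bearing aryl alone is what compound 3 shares with the step from compound 1, a return toward the number of compound 1 is expected, but with wide uncertainty; the estimated step is a number 10 percentage points higher from compound 2 to compound 3 (within the scatter). For compound 3 the expected value in this assay is 70%, within 50% to 90%.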

Compound 3, a percentage reported as activity, at one concentration (the size of the read-out at that concentration, not a potency): 90%
Estimate against measurement, compound 3: 20 percentage points below; low and high end bracket the measured number.
By their numbers in this assay, from the lowest: compound 2; then compounds 1 and 3 (each within the scatter of the next).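

In this assay, going by these compounds alone, the saturated ring carbon next to the ring atom that bears a cyano group is no longer tied to an aryl group attached directly: 2-phenylethenyl in place of 4-hydroxyphenyl gives a number 30 percentage points higher from compound 2 to compound 3 (beyond the scatter), the first change that raises the number from compound 2. The exchange of 4-methylphenyl for the same group gives a number 10 percentage points higher from compound 1 to compound 3 (within the scatter), so this position accepts either of these two groups without a readable difference, and among the three compounds only the hydroxy-bearing compound 2 stands apart, lowest of the set. Nothing available here accounts for these differences.

The compounds shown do not separate the role of the double bond in 2-phenylethenyl from that of the attached phenyl ring, a question that a saturated 2-phenylethyl group or a simple ethenyl group on the same carbon would address. Going by these compounds, it also remains open whether a polar group such as a carboxylic acid or an amine at the end of such a chain would lower the number as the hydroxy-bearing compound 2 does.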